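From Cyclohexyl to 3-Methoxyphenyl on an Aromatic Nitrogen

A few compounds are considered here, and "the series" means these few. Any claim that something is new, unique, unknown or untested is made for them only; others in the source may bear on it.

Of the compounds shown here, two have so far been measured in an ADME assay on CHO-K1 cells (Cricetulus griseus) for cytotoxicity, read by MTT assay, with a stated time of 24 h; a lower number here means a stronger inhibitor, a higher number a weaker inhibitor. Compound 1 `COc1ccc(Cn2nnc(-c3cc([N+](=O)[O-])cc([N+](=O)[O-])c3)n2)cc1` gives 96000 nM in this assay. Compound 2 `O=[N+]([O-])c1cc(-c2nnn(CSc3nnnn3C3CCCCC3)n2)cc([N+](=O)[O-])c1` gives 140000 nM in this assay, the higher of the two numbers, though its gap to compound 1 falls within the scatter of repeated measurements. Compound 3 `COc1cccc(-n2nnnc2SCn2nnc(-c3cc([N+](=O)[O-])cc([N+](=O)[O-])c3)n2)c1` differs from compound 2 in one place: 3-methoxyphenyl in place of cyclohexyl on an aromatic nitrogen. Among the measured compounds shown here, no step between measured compounds matches this change, and compounds 1 and 2 together show only that two different groups on the shared core both land in the same weakly inhibiting region. With nothing to point one way or the other, the expected step of no change at the digits printed from compound 2 to compound 3 (within the scatter) is taken to lie within the scatter, in no particular direction. Compound 3 is accordingly estimated at 140000 nM in this assay, with a range from 60000 nM to 320000 nM.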

Compound 3, half-maximal inhibitory concentration: 135000 nM
Estimate against measurement, compound 3: 1.0-fold (0.02 log units) above; low and high end bracket the measured number.
By their numbers in this assay, from the lowest: compounds 1, 3 and 2 (each within the scatter of the next).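

In this assay, among the compounds shown here, the exchange of cyclohexyl for 3-methoxyphenyl on an aromatic nitrogen gives a 1.0-fold lower number from compound 2 to compound 3 (0.02 log units; within the scatter), which is the first comparison at this position that differs in one place only. For the compounds shown here, a six-membered non-aromatic ring of carbon only gives way to a six-membered aromatic ring of carbon only that carries a methoxy group, and the two compounds cannot be told apart in this read-out. Nothing at hand offers an explanation for this result.

On these data alone, what an amine or a carboxylic acid on this aromatic nitrogen would do to the number remains open, so it is not yet known whether any group here can move it beyond the scatter. Also open, as far as these compounds go, is whether the same exchange would read alike on a core other than that of compound 2.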